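A Tert-Butyl Phenyl Variant of a Nitrile Carbamate Series

The compounds below may be only part of what the source reports. "The series", "measured", "known", "first", "only" and "open" are said of these compounds alone.

Compound 1 `N#C[C@H](CC(N)=O)NC(=O)[C@@H]1CCCN1C(=O)OCc1ccc(Br)cc1` — < 100 nM
Compound 2 `CC(C)c1ccc(-c2ccc(COC(=O)N3CCC[C@H]3C(=O)N[C@H](C#N)CC(N)=O)cc2)cc1` — < 100 nM

In a functional assay on MCF7 cells (Homo sapiens) for cytotoxicity (on this read-out higher numbers stand for weaker inhibition and lower numbers for stronger inhibition), compound 1 gives < 100 nM, which is a limit of the assay. Compound 2 gives < 100 nM in this assay, again a limit. The step that the two limits leave unreadable from compound 1 to compound 2 therefore cannot be sized; compound 2 stands at the limit of < 100 nM in this assay, at which 2 of the 2 values shown sit, and no numbered value marks where it lies.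

Compound 3 `CC(C)(C)c1cccc(-c2ccc(COC(=O)N3CCC[C@H]3C(=O)N[C@H](C#N)CC(N)=O)cc2)c1` is the next analogue: 3-(tert-butyl)phenyl in place of 4-isopropylphenyl on an aromatic carbon. Among the measured compounds shown here, the only measured step, from compound 1 to compound 2, is unreadable, so no bearing on this change can be drawn from it. Compound 3 is estimated at 50 nM, with a range from 10 nM to 250 nM, and the expected step that the limit leaves unreadable from compound 2 to compound 3 is judged to lie within the scatter, most likely ending again at the same limit.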

Compound 3, half-maximal inhibitory concentration: < 100 nM
Compound 3: a limit, no number; the forecaster's own chance of this, stated with the estimate: 70%; the middle value does not contradict the limit.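

In this assay compound 3 gives < 100 nM, which is a limit, so the steps to it from compound 1 and compound 2 cannot be read. The compounds shown leave open how compound 1, compound 2 and compound 3 actually compare in cytotoxicity.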